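This account rests on a few compounds, and the source may have more. Where it says the series, first, only, none or still open, it means among the compounds named here.

Compound 1 `C[C@H](c1c[nH]c2ccccc12)[C@@H]1SC(N)=NC1=O` and compound 2 `CNC1=NC(=O)[C@H]([C@H](C)c2c[nH]c3ccccc23)S1` share the same core. In an ADME assay on HeLa cells (Homo sapiens) for cytotoxicity, read by neutral red uptake (on this read-out higher numbers stand for lower toxicity in this test and lower numbers for higher toxicity in this test), compound 1 is recorded as "not determined" (no result reported), so no result was reported for it. Within the data shown here, compound 2 is thus the only compound with a number in this assay, where compound 2 gives 30 ug/mL. Compound 3 `C[C@H](c1c[nH]c2ccccc12)[C@@H]1SC(NCCO)=NC1=O` has not yet been measured in this assay. Compound 3 differs from compound 2 by hydroxymethyl in place of hydrogen on a saturated chain carbon bound to an amine nitrogen. No step between two measured compounds is available here, so nothing in the data shows how the minimum cytotoxic concentration responds to a change of this kind in this series. The change is expected to move the read-out little, with a step that is estimated at no change at the digits printed from compound 2 to compound 3 (within the scatter) and that stays within the usual scatter. Compound 3 is therefore expected to give about 30 ug/mL in this assay, with a likely range from 15 ug/mL to 60 ug/mL.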

Compound 3, minimum cytotoxic concentration: > 100 ug/mL
Compound 3: a limit, no number; the forecaster's own chance of this, stated with the estimate: 10%; at least 3.3-fold (0.52 log units) between middle value and limit.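

In this assay, the change on a saturated chain carbon bound to an amine nitrogen is not silent: hydroxymethyl in place of hydrogen gives an at least 3.3-fold higher number from compound 2 to compound 3 (0.52 log units; beyond the scatter), and a higher number here stands for lower toxicity in this test. From the compounds shown here alone, compound 3 gives > 100 ug/mL, which is a limit of the assay and not a number, so the true size of the step remains unknown. Among these compounds, this single pair is the first readable step at this position, and it shows that methylamino and (2-hydroxyethyl)amino do not read alike here.

The compounds shown leave open whether the hydroxyl or the added carbon carries the step, a question that an ethyl group in place of the 2-hydroxyethyl would address. They also leave open how a longer chain, or an amine or a carboxylic acid at the chain end, would read.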